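A methyl for a fluoro on the benzyl ring

The source may hold more compounds than are shown below. What is called first, only, known or untested is meant among the compounds shown, and "the series" means these compounds.

Compound 1 `CN(C)/N=C1/CN(CC(=O)Nc2cccc(-c3cnn(C)c3)c2)C(=O)C(Cc2c(Cl)cccc2Cl)CN1` is the measured anchor of this small set. In an assay on isolated protein for inhibition of kallikrein-7 (Mus musculus), read by fluorescence, with stated times of 10 min and 30 min (a higher number here means a weaker inhibitor, a lower number a stronger inhibitor), compound 1 gives 1200 nM; 16000 nM; 700 nM (3 entries), three entries that do not agree closely (the several entries of compound 1 in this assay, 1200 nM; 16000 nM; 700 nM (3 entries)). Compound 2 `CN(C)/N=C1/CN(CC(=O)Nc2cccc(-c3cnn(C)c3)c2)C(=O)C(Cc2c(F)cccc2F)CN1` shares the core of compound 1 and differs in the two groups on the benzyl ring. In this assay compound 2 gives only a limit of the assay, > 30000 nM, so no single number places it (the limit of > 30000 nM in this assay, at which 1 of the 2 values shown sits). Compound 3 `Cc1cccc(F)c1CC1CN/C(=N\N(C)C)CN(CC(=O)Nc2cccc(-c3cnn(C)c3)c2)C1=O`, not yet measured, differs from compound 2 by methyl in place of fluoro on an aromatic carbon. Among the compounds with values here, no measured pair covers this exact change, so the expectation rests on the two measured compounds: compound 1 yields measurable inhibition, while compound 2 reaches only the limit. The methyl is expected to carry compound 3 back toward a measurable number, and the expected step of an at least 3.0-fold lower number from compound 2 to compound 3 (0.47 log units; beyond the scatter) is modest and uncertain. Compound 3 is therefore estimated at 10000 nM, with a range from 2000 nM to 40000 nM.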

Compound 3, half-maximal inhibitory concentration: 7700 nM
Compound 3: middle estimate off by 1.3-fold (0.11 log units), on the high side; the range from low to high includes it.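

Replacing one fluoro with methyl, which turns 2,6-difluorobenzyl into 2-fluoro-6-methylbenzyl, now stands as a single measured change in this assay, and it gives an at least 3.8-fold lower number from compound 2 to compound 3 (0.59 log units; beyond the scatter). That step has only a lower bound, since compound 2 supplies a limit of the assay and not a number: the limit of > 30000 nM in this assay, at which 1 of the 3 values shown sits. Fluoro and methyl each count one heavy atom, and no ring, hydrogen-bond donor or acceptor enters or leaves, yet this single exchange on the benzyl ring moves the result beyond the scatter.

From the compounds shown here alone, whether the lower number belongs to the methyl or to the loss of the fluoro stays open, and a hydrogen or an ethyl at this place would speak to that. Compound 1 differs from compound 3 in two places and offers no clean reference, and its own entries do not agree closely: the several entries of compound 1 in this assay, 1200 nM; 16000 nM; 700 nM (3 entries).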